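The compounds below may be only part of what the source reports. "The series", "measured", "known", "first", "only" and "open" are said of these compounds alone.

Compound 2 `CNc1nc2c(ncn2-c2ccccc2)c(=O)n1-c1ccc(Cl)cc1` carries a chloro group on one of its two phenyl rings, and its near relative compound 1 `CNc1nc2c(ncn2-c2ccccc2)c(=O)n1-c1ccccc1` carries hydrogen in that place. Both were tested in a functional assay on HepG2 cells (Homo sapiens) for cytotoxicity, read by MTT assay, with a stated time of 72 h; a lower number here means a stronger inhibitor, a higher number a weaker inhibitor. Compound 1 reaches only the limit of the measurement, shown as > 100000 nM. Compound 2 likewise reaches only that limit, shown as > 100000 nM. Among the measured compounds shown here, the one step between them, a step that the two limits leave unreadable from compound 1 to compound 2, cannot be read in size, since both ends sit at the limit. So compound 2 stands at the limit of > 100000 nM in this assay, at which 2 of the 2 values shown sit, with no number of its own. Compound 3 `O=c1c2ncn(-c3ccccc3)c2nc(NCc2ccccc2)n1-c1ccc(Cl)cc1` differs from compound 2 by phenyl in place of hydrogen on a saturated chain carbon bound to a nitrogen on an aromatic ring, that is, the methyl group on the amine becomes a benzyl group. For the measured compounds named here, no measured step touches this part of the molecule, so the only guide is that neither compound 1 nor compound 2 shows any readable inhibition in this assay. The step from compound 2 to compound 3 is therefore expected to be a step that the limit leaves unreadable from compound 2 to compound 3, meaning no clear change. Compound 3 is expected to give about 120000 nM, between 30000 nM and 500000 nM, most likely again only as a limit.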

Compound 3, half-maximal inhibitory concentration: 62100 nM
The estimate for compound 3 lay 1.9-fold (0.29 log units) above the measured number; low and high end bracket the measured number.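

Replacing methylamino with benzylamino yields the only true number among the compounds shown: in this assay compound 3 gives 62100 nM as a measured value rather than a limit. Among the compounds shown here, the other two compounds stay at the limit of the test, so only this change shows that the group on the amine nitrogen can bring a compound into the readable range: the limit of > 100000 nM in this assay, at which 2 of the 3 values shown sit. The measured change is an at least 1.6-fold lower number from compound 2 to compound 3 (0.20 log units; that floor lies within the scatter) and gives only a floor, so the real change may be larger, but the floor alone does not clear the usual scatter.

The compounds shown leave open whether the aromatic ring itself matters, or whether a butyl chain or a cyclohexylmethyl group on the amine would give a similar result. Benzylamino also appears here only together with the chloro group, so whether chloro has any effect once the compound gives a readable value remains open.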